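Swapping the Aryl Group on the Ring Nitrogen

The compounds below may be only part of what the source reports. "The series", "measured", "known", "first", "only" and "open" are said of these compounds alone.

Of the compounds shown here, three from one series have been measured in a functional assay on HCT-116 cells (Homo sapiens) for inhibition, read by sulforhodamine B assay, with a stated time of 48 h, tested at 50 uM; a higher number here means more inhibition of growth at the concentration tested, a lower number less inhibition of growth. Compound 1 `COc1cc2c(cc1CC=C(C)C)/C(=N/NC(N)=O)C[C@@H](c1ccc(O)cc1)O2` gives 87%. Compound 2 `COc1ccc([C@@H]2C/C(=N/OCc3cn(-c4ccccc4CO)nn3)c3cc(CC=C(C)C)c(OC)cc3O2)cc1` gives 100%, and compound 3 `COc1cc2c(cc1CC=C(C)C)C(=O)C[C@@H](c1ccc(Oc3ccc(F)cc3)cc1)O2` gives 29%. Compound 2 therefore stands highest of the three numbers; compound 1 comes nearest, with a number lower by more than the usual scatter, and compound 3 lies furthest below, also beyond the scatter. No two of these compounds differ in a single place, so none of these gaps can be tied to one structural change.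

Compound 4 `COc1ccc([C@@H]2C/C(=N/OCc3cn(-c4ccc(O)cc4)nn3)c3cc(CC=C(C)C)c(OC)cc3O2)cc1` has not yet been measured. It differs from compound 2 in one place: 4-hydroxyphenyl in place of 2-(hydroxymethyl)phenyl on an aromatic nitrogen. The rest of the molecule, including the shared core of compound 2, is kept as it is.

For a change this contained, the step of a number 7 percentage points lower from compound 2 to compound 4 (within the scatter) in this assay is expected to stay within the usual scatter, with no clear direction. Compound 4 is thus expected to come in near 93%, with a likely range from 75% to 100%.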

Compound 4, percent growth inhibition at one concentration: 65%
Beside the measured number, compound 4's estimate is 28 percentage points above it; the whole stated range lies above it.
By their numbers in this assay, from the lowest: compound 3; then compound 4; then compound 1; then compound 2.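

The aryl group on this aromatic nitrogen clearly matters in this assay: putting 4-hydroxyphenyl in place of 2-(hydroxymethyl)phenyl gives a number 35 percentage points lower from compound 2 to compound 4 (beyond the scatter), a large step for a single contained change. The two groups look alike by simple counts, since each has one six-membered aromatic ring of carbon only, the same numbers of hydrogen-bond donors and acceptors, and no net charge, so these counts alone do not predict the outcome here. No measurement at hand explains the drop.

Two groups cannot show whether the step follows the change from hydroxymethyl to hydroxy or the different place of the group on the phenyl ring. On these data alone, how a phenyl ring carrying an amine or a carboxylic acid would behave on this nitrogen also remains open.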